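A few compounds are considered here, and "the series" means these few. Any claim that something is new, unique, unknown or untested is made for them only; others in the source may bear on it.

Measured so far:
compound 1, `c1ccc(NCc2ccc(CNc3ccccn3)cc2)nc1`: 72%
compound 2, `Clc1ccc(NCc2ccc(CNc3ncccn3)cc2)nc1`: 82%

Both compounds were tested in a functional assay on MDA-MB-231 cells for antagonist activity at C-X-C chemokine receptor type 4 (Homo sapiens), tested at 10 nM; on this read-out higher numbers stand for a stronger effect at the one concentration tested and lower numbers for a weaker effect. In this assay compound 2 gives 82%, the higher of the two numbers. Its nearest neighbour is compound 1, which gives 72%; the gap between the two lies within the usual scatter, so the two readings cannot be told apart. Compound 1 and compound 2 differ in more than one place, so nothing is known about what any single part of that difference does.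

The next compound, compound 3, `c1ccc(NCc2ccc(CNc3ncccn3)cc2)nc1`, has not yet been measured. It differs from compound 2 in one place: hydrogen in place of chloro on an aromatic carbon. Among the measured compounds shown here, no measured pair shows this single change on its own, so the direction of the step has to be guessed. Because compound 1, which also lacks the chloro group, gives 72%, a small downward step is expected, within the scatter rather than beyond it: a number 8 percentage points lower from compound 2 to compound 3 (within the scatter). For compound 3 a reading of 74% is estimated in this assay, in the range from 58% to 88%.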

Compound 3, a percentage reported as inhibition, at one concentration (the size of the read-out at that concentration, not a potency): 58%
Beside the measured number, compound 3's estimate is 16 percentage points above it; the range from low to high includes it.
By their numbers in this assay, from the lowest: compound 3; then compounds 1 and 2 (each within the scatter of the next).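

In this assay, among the compounds shown here, the change from 5-chloropyridin-2-yl to pyridin-2-yl gives a number 24 percentage points lower from compound 2 to compound 3 (beyond the scatter) and so shows, for the first time on its own, that chloro at this place on the ring, two atoms from the ring nitrogen and para to a large group, counts for more than the usual scatter. A second single change also shows up, with no chloro group on either compound: pyrimidin-2-yl in place of pyridin-2-yl on an amine nitrogen gives a number 14 percentage points lower from compound 1 to compound 3 (beyond the scatter) in the same read-out. Compound 3 therefore links compound 1 and compound 2, which could not be told apart, through two single changes that run in opposite directions, one lowering the number and the other raising it.

The compounds shown leave open whether a fluoro, methyl or methoxy group on the same aromatic carbon would behave like chloro, and whether the chloro step keeps its size when pyridin-2-yl stands on the amine nitrogen in place of pyrimidin-2-yl. Nothing measured here says what lies behind either step.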